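Acetyl for cyano on the propyl chain of compound 1

The source may hold more compounds than are shown below. What is called first, only, known or untested is meant among the compounds shown, and "the series" means these compounds.

Measured compounds in a functional assay (trachea) with Cavia porcellus as the target; a lower number here means that less compound is needed, a higher number that more compound is needed for the effect:
- compound 1 `CCCn1c(=O)n(CCC#N)c(=O)c2[nH]cnc21`: 1700 nM
- compound 2 `CCCn1c(=O)n(CCCN(C)C)c(=O)c2[nH]cnc21`: 20500 nM
- compound 3 `CCCn1c(=O)n(CCCO)c(=O)c2[nH]cnc21`: 5100 nM

Compound 1 gives the lowest number of the three in this assay. Its nearest neighbour is compound 3, reached by a 3.0-fold higher number from compound 1 to compound 3 (0.48 log units; beyond the scatter), and the furthest is compound 2, reached by a 12-fold higher number from compound 1 to compound 2 (1.08 log units; beyond the scatter). Between those two, a 4.0-fold lower number from compound 2 to compound 3 (0.60 log units; beyond the scatter) closes the set.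

Compound 4 `CCCn1c(=O)n(CCC(C)=O)c(=O)c2[nH]cnc21` has not been measured. It differs from compound 1 in one place: acetyl in place of cyano on a saturated chain carbon, two bonds along the chain from an aromatic nitrogen. Both measured steps from compound 1 bear on this change, since each replaces the cyano at the same position; both raised the number, the (dimethylamino)methyl step by a large margin and the hydroxymethyl step by a modest one. Acetyl, like cyano, brings no donor and one acceptor and no charge, so compound 4 is expected to sit nearer the hydroxymethyl case, with a modest rise beyond the scatter rather than a large one. The estimate for compound 4 in this assay is therefore 4000 nM, with a range from 1500 nM to 11000 nM, meaning an expected step of a 2.4-fold higher number from compound 1 to compound 4 (0.37 log units; beyond the scatter).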

Compound 4, half-maximal effective concentration: 3500 nM
Compound 4: middle estimate off by 1.1-fold (0.06 log units), on the high side, within the range that was stated.
By their numbers in this assay, from the lowest: compound 1; then compounds 4 and 3 (each within the scatter of the next); then compound 2.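

In this assay, acetyl in place of cyano gives a 2.1-fold higher number from compound 1 to compound 4 (0.31 log units; beyond the scatter), so all three groups shown in place of the cyano on this chain give a higher number than the nitrile of compound 1. The acetyl and hydroxymethyl groups are not separated at this position, with a 1.5-fold lower number from compound 3 to compound 4 (0.16 log units; within the scatter), while a 5.9-fold lower number from compound 2 to compound 4 (0.77 log units; beyond the scatter) leaves the (dimethylamino)methyl group of compound 2 apart from the others. Nothing measured here accounts for these differences.

From the compounds shown here alone, whether a carboxylic acid, a primary amide or a longer chain ending in a nitrile would match compound 1 at this place remains open. So does whether any group on this chain can give a lower number than the cyano does.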